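Swapping the piperidinyl for trifluoromethylphenyl on the benzylic carbon

This account rests on a few compounds, and the source may have more. Where it says the series, first, only, none or still open, it means among the compounds named here.

Measured so far:
compound 1 `CNC(=O)c1nc(C)c2c(c1N)C(=O)N(Cc1ccccc1)C2=O` — 41000 nM
compound 2 `Cc1noc(-c2nc(C)c3c(c2N)C(=O)N(CC2CCNCC2)C3=O)n1` — 160000 nM

In a physicochemical assay for solubility, using the shake flask method, in simulated intestinal fluid, measured as kinetic solubility, with a stated time of 2 h, at 25 degrees C, at pH 6.5 (on this read-out lower numbers stand for lower solubility and higher numbers for higher solubility), compound 1 gives 41000 nM. In this assay compound 2 gives 160000 nM, the higher of the two numbers; the gap between compound 2 and compound 1 lies beyond the scatter. Compound 3 `Cc1noc(-c2nc(C)c3c(c2N)C(=O)N(Cc2ccccc2C(F)(F)F)C3=O)n1` has not been measured yet. It differs from compound 2 in one place: 2-(trifluoromethyl)phenyl in place of piperidin-4-yl on a saturated chain carbon bound to an amide-type nitrogen in a ring.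

Compound 1 carries a benzyl group at the same kind of position and sits well below compound 2, so the step from compound 2 to compound 3 is expected to run downward, by more than the scatter, as an estimated 20-fold lower number from compound 2 to compound 3 (1.30 log units; beyond the scatter). With that expectation, compound 3 is estimated at 8000 nM in this assay, within a range from 1500 nM to 40000 nM.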

Compound 3, solubility: < 5000 nM
Compound 3 was reported as a limit (the forecaster's own chance of this, stated with the estimate: 10%); middle value at least 1.6-fold (0.20 log units) from the limit.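

In this assay, among these compounds, putting 2-(trifluoromethyl)phenyl in place of piperidin-4-yl on a saturated chain carbon bound to an amide-type nitrogen in a ring gives an at least 32-fold lower number from compound 2 to compound 3 (1.50 log units; beyond the scatter), the first reading of a change in one place in these compounds, and it shows that this position responds strongly to the group it carries. On these data alone, compound 3 is reported as a limit, < 5000 nM, so the step gives only a minimum size and its full extent stays unknown. The reading at this end of the scale is bounded by the assay: the limit of < 5000 nM in this assay, at which 1 of the 3 values shown sits.

The compounds shown leave open whether the step follows the loss of the ring nitrogen, the arrival of the aromatic ring or the trifluoromethyl group. A cyclohexyl group on the same carbon, with the core shared by compound 2 and compound 3, would set the ring nitrogen apart from the rest of the change.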